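Para-substituent swap on the styryl ring: methoxy for methylsulfanyl

The source may report more compounds than this note shows. Statements on the series, on what has been measured and on what is new or still open speak of the compounds shown alone.

The series shares one core, varied only at the substituted benzene ring. Compound 1 `CC(=O)c1ccc(/C=C2\CCCN=C2c2cccnc2)cc1` carries an acetyl group there and in an assay on membranes from brain for displacement of a labelled ligand from Neuronal acetylcholine receptor; alpha4/beta2 (Rattus norvegicus), with a stated time of 3 h (a lower number here means a stronger inhibitor, a higher number a weaker inhibitor), compound 1 gives 4490 nM. Compound 2 `CSc1ccc(/C=C2\CCCN=C2c2cccnc2)cc1` carries a methylsulfanyl group instead; in this assay compound 2 gives 900 nM. Compound 3 `Cc1cc(/C=C2\CCCN=C2c2cccnc2)cc(C)c1O`, with a hydroxy flanked by two methyls, gives 360 nM in this assay.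

Among the three numbers compound 2 stands second highest: compound 3 sits below it and compound 1 above it. Among the compounds with values here, the one measured step that involves compound 2 is a 5.0-fold lower number from compound 1 to compound 2 (0.70 log units; beyond the scatter).

Compound 4 `COc1ccc(/C=C2\CCCN=C2c2cccnc2)cc1` is the next member. It differs from compound 2 in one place: methoxy in place of methylsulfanyl on an aromatic carbon. Within the data shown here, the change is small in size, and no measured pair in this set exchanges these two groups, so the acetyl-to-methylsulfanyl step is the only guide, and it concerns a different pair of groups. A step of no more than modest size is therefore expected in this assay, in either direction, most likely close to the scatter.

The estimated step from compound 2 to compound 4 is a 1.1-fold lower number from compound 2 to compound 4 (0.05 log units; within the scatter). Compound 4 is expected to give about 800 nM in this assay, within a range from 300 nM to 2200 nM.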

Compound 4, inhibition constant: 490 nM
Compound 4: middle estimate off by 1.6-fold (0.21 log units), on the high side; measured number inside the range.
By their numbers in this assay, from the lowest: compounds 3, 4 and 2 (each within the scatter of the next, the first and the last beyond it); then compound 1.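

In this assay, within the data shown here, methoxy in place of methylsulfanyl on an aromatic carbon, para to a large group, gives a 1.8-fold lower number from compound 2 to compound 4 (0.26 log units; within the scatter) and so leaves the two groups indistinguishable at this position, which the earlier compounds could not show as no measured pair exchanged them. Set against acetyl, methoxy gives a 9.2-fold lower number from compound 1 to compound 4 (0.96 log units; beyond the scatter) as its step, and with a 5.0-fold lower number from compound 1 to compound 2 (0.70 log units; beyond the scatter) also on record, compound 1 stands apart from both compound 2 and compound 4, so among these three groups on the same core only acetyl separates from the others. Nothing measured on these compounds bears on why methoxy and methylsulfanyl read alike or why acetyl differs from both.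

Still open, as far as these compounds go, is whether the match between methoxy and methylsulfanyl extends to a longer chain such as ethoxy or propoxy, or to an amine such as dimethylamino, at this same position. Also open, from the compounds shown here alone, is whether the result for compound 1 belongs to acetyl alone or is shared by other carbonyl-bearing groups, such as a carboxylic acid, an ester or an amide.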